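A few compounds are considered here, and "the series" means these few. Any claim that something is new, unique, unknown or untested is made for them only; others in the source may bear on it.

Measured in a functional assay on RL cells (Homo sapiens) for cytotoxicity, with a stated time of 48 h; on this read-out higher numbers stand for weaker inhibition and lower numbers for stronger inhibition:
compound 1 `COc1cc(OC)c(C(=O)/C=C/c2ccccc2OC)c(OC)c1`: 9000 nM
compound 2 `COc1cccc(/C=C/C(=O)c2c(OC)cc(OC)cc2OC)c1`: 5900 nM
compound 3 `COc1cc(OC)c(C(=O)/C=C/c2ccc(Cl)cc2)c(OC)c1`: 6500 nM

Compound 3 cannot be separated from the other two compounds on these numbers. The data show a 1.4-fold lower number from compound 1 to compound 3 (0.14 log units; within the scatter) and a 1.1-fold higher number from compound 2 to compound 3 (0.04 log units; within the scatter), and both lie within the scatter.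

Compound 4 `COc1cc(OC)c(C(=O)/C=C/c2ccc([N+](=O)[O-])cc2)c(OC)c1` keeps the shared core of compound 3 and changes one group: nitro in place of chloro on an aromatic carbon. In words, this is nitro in place of chloro on an aromatic carbon, para to a large group. Among the measured compounds shown here, no measured step covers this exchange directly. The closest evidence comes from swaps of the aryl group on the same chain carbon, which gave a 1.5-fold lower number from compound 1 to compound 2 (0.18 log units; within the scatter) alongside the two steps above. None of these steps exceeds the scatter, so no step beyond the scatter is expected in this assay, although three compounds are a thin basis. The expected change is a 1.3-fold lower number from compound 3 to compound 4 (0.11 log units; within the scatter). For compound 4 the estimated value is 5000 nM, with an expected range of 2000 nM to 12000 nM.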

Compound 4, half-maximal inhibitory concentration: 3400 nM
Beside the measured number, compound 4's estimate is 1.5-fold (0.17 log units) above it, within the range that was stated.
By their numbers in this assay, from the lowest: compounds 4, 2, 3 and 1 (each within the scatter of the next, the first and the last beyond it).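

In this assay, nitro in place of chloro on an aromatic carbon, para to a large group, gives a 1.9-fold lower number from compound 3 to compound 4 (0.28 log units; within the scatter) and so stays within the scatter. The earlier compounds shown here differed in the whole aryl group on the chain, whereas this pair isolates a single group at one place on that ring. There, three heavy atoms and two hydrogen-bond acceptors replace one chlorine and no acceptors without a step beyond the scatter, though this rests on one pair. Nothing available here bears on what lies behind this result.

The compounds shown leave open whether an amine or a carboxylic acid at this place would also stay within the scatter. They also leave open whether nitro elsewhere on the same ring would behave as it does here.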